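The source may report more compounds than this note shows. Statements on the series, on what has been measured and on what is new or still open speak of the compounds shown alone.

Measured so far:

Compound 1 `Cc1nn(-c2ccccn2)c2cc(-c3ccc(CCC(=O)O)cc3C#N)ccc12`: in a physicochemical assay for lipophilicity, using the shake flask method, measured as octanol-water partition, with a stated time of 30 min, at pH 7.4 (on this read-out lower numbers stand for lower lipophilicity and higher numbers for higher lipophilicity), compound 1 gives 2.2.
Compound 2 `Cc1nn(-c2ccccn2)c2cc(-c3ccc(CCC(=O)O)cc3F)ccc12`: compound 2 gives 2.9.
Compound 3 `O=C(O)CCc1ccc(-c2cc(F)c3cnn(-c4ccccn4)c3c2)cc1`: compound 3 gives 2.8.

Compound 2 and compound 1 share a core and differ in one place: cyano in place of fluoro on an aromatic carbon. This change gave a number 0.70 log units lower from compound 2 to compound 1 (beyond the scatter). Compound 3 has a different core from compound 2, and the difference between the two cores is not broken down here; their two values lie within the scatter of each other, so no order is claimed between them.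

Compound 4 `N#Cc1cc(-c2ccc(CCC(=O)O)cc2)cc2c1cnn2-c1ccccn1` is not yet measured. It differs from compound 3 in one place: cyano in place of fluoro on an aromatic carbon. Among the measured compounds shown here, this is the same kind of change as the one from compound 2 to compound 1, not the same change, since the place differs: in compound 4 the group sits on a ring that is part of a fused or bridged system of two rings, ortho to a fused ring, meta to a fused ring and meta to a large group, whereas in compound 1 it sits ortho to a large group and meta to a 2-carboxyethyl group.

For compound 4 in this assay an expected step of a number 0.65 log units lower from compound 3 to compound 4 (beyond the scatter) follows, because a number 0.70 log units lower from compound 2 to compound 1 (beyond the scatter) was seen for the same kind of change. The estimate for compound 4 is 2.15, expected between 1.7 and 2.6.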

Compound 4, distribution coefficient: 2.2
Estimate against measurement, compound 4: 0.05 log units below; the range from low to high includes it.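

In this assay, cyano in place of fluoro gave a number 0.60 log units lower from compound 3 to compound 4 (beyond the scatter) in this pair, while the same kind of change on the other core gave a number 0.70 log units lower from compound 2 to compound 1 (beyond the scatter) in the earlier pair. Both steps point the same way and both lie beyond the scatter, so in these two pairs the change carried over from one core to the other, even though the group sits in a different place on each core. Two pairs do not make a rule for the whole series, however, and nothing shown here explains why the number falls with this change.

As far as these compounds go, how a chloro or a trifluoromethyl group in the same place would compare with fluoro and cyano stays open. Also open, from the compounds shown here alone, is whether cyano in place of fluoro gives a step of this kind at other places on these rings, or on a core without the 2-carboxyethyl group.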